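This account rests on a few compounds, and the source may have more. Where it says the series, first, only, none or still open, it means among the compounds named here.

Compound 1 `CCN(CC)c1ccc(C(F)(F)F)cc1NC(=O)c1cccnc1`, compound 2 `O=C(Nc1cc(C(F)(F)F)ccc1NC1CCCCC1)c1ccncc1` and compound 3 `O=C(Nc1cc(C(F)(F)F)ccc1NC1CCCCC1)c1cccnc1` share one core and have been measured; compound 4 `CCN(CC)c1ccc(C(F)(F)F)cc1NC(=O)c1ccncc1` has not. In a functional assay on HL-60 cells (Homo sapiens) for cytotoxicity, read by MTT assay, with a stated time of 48 h (a higher number here means a weaker inhibitor, a lower number a stronger inhibitor), compound 1 gives 71000 nM. In this assay compound 2 gives 59200 nM, and compound 3 gives 48300 nM. Compound 2 stands second highest of the three numbers, with compound 1 nearest and compound 3 furthest, and all three lie within the scatter of one another, so no order among them can be claimed. Compound 4 differs from compound 2 by diethylamino in place of cyclohexylamino on an aromatic carbon. The measured step that bears on this is the one in the opposite direction, a 1.5-fold lower number from compound 1 to compound 3 (0.17 log units; within the scatter), made on the pyridin-3-yl amides; the other step, a 1.2-fold lower number from compound 2 to compound 3 (0.09 log units; within the scatter), concerns the carbonyl-side ring and does not touch this change. Reversing the measured step, a slightly higher number is expected for compound 4, a 1.4-fold higher number from compound 2 to compound 4 (0.13 log units; within the scatter), with no shift beyond the scatter. The estimate for compound 4 in this assay is 80000 nM, in a range from 45000 nM to 140000 nM.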

Compound 4, half-maximal inhibitory concentration: 89700 nM
Estimate against measurement, compound 4: 1.1-fold (0.05 log units) below; low and high end bracket the measured number.
By their numbers in this assay, from the lowest: compounds 3, 2, 1 and 4 (each within the scatter of the next).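

Compound 4 lets the swap of cyclohexylamino for diethylamino on the aromatic carbon be read on the pyridin-4-yl amides as well, where this assay gives a 1.5-fold higher number from compound 2 to compound 4 (0.18 log units; within the scatter), and the change keeps its size on both cores: the same change on two cores in this assay, a 1.5-fold lower number (0.17 log units; within the scatter) from compound 1 to compound 3 and a 1.5-fold lower number (0.18 log units; within the scatter) from compound 4 to compound 2, 1.0-fold (0.01 log units) apart, within the scatter of two such steps

The carbonyl-side change can now also be read on the diethylamino amides, as a 1.3-fold higher number from compound 1 to compound 4 (0.10 log units; within the scatter), and it too keeps its size: the same change on two cores in this assay, a 1.2-fold lower number (0.09 log units; within the scatter) from compound 2 to compound 3 and a 1.3-fold lower number (0.10 log units; within the scatter) from compound 4 to compound 1, 1.0-fold (0.01 log units) apart, within the scatter of two such steps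

Each change therefore reads the same on either core, but every step stays within the scatter, so neither change can be said to move the number in these four compounds.

Open, on these data alone, is whether any group at this aromatic carbon, such as a carboxylic acid or a longer chain like octylamino, would shift the number beyond the scatter. The same question holds for a phenyl ring in place of pyridin-3-yl or pyridin-4-yl on the carbonyl carbon.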